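This account rests on a few compounds, and the source may have more. Where it says the series, first, only, none or still open, it means among the compounds named here.

Compound 1 `COc1ccc(S(=O)(=O)N(CC(N)=O)c2ccc(N(CC(N)=O)S(=O)(=O)c3ccc([S+]([O-])CCCCN=C=S)cc3)c3ccccc23)cc1`: > 10000 nM, a limit of the assay
Compound 2 `COc1ccc(S(=O)(=O)N(CC(N)=O)c2ccc(N(CC(N)=O)S(=O)(=O)c3ccc(S(=O)(=O)CCCCCN=C=S)cc3)c3ccccc23)cc1`: > 10000 nM, a limit of the assay

Both values come from an ADME assay on cells (Peritoneal macrophage, Mus musculus) for cytotoxicity, read by CCK-8 assay, with a stated time of 24 h; on this read-out higher numbers stand for lower toxicity in this test and lower numbers for higher toxicity in this test. Neither is a number, and together they make up the whole record so far: the limit of > 10000 nM in this assay, at which 2 of the 2 values shown sit. Compound 2 therefore stands only at its limit of > 10000 nM.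

Compound 3 `COc1ccc(S(=O)(=O)N(CC(N)=O)c2ccc(N(CC(N)=O)S(=O)(=O)c3ccc(N=C=S)cc3)c3ccccc23)cc1` has not yet been measured. It differs from compound 2 in one place: a group of 3 heavy atoms (1 carbon, 1 nitrogen, 1 sulfur; no ring) in place of a group of 11 heavy atoms (6 carbon, 1 nitrogen, 2 oxygen, 2 sulfur; no ring), on an aromatic carbon. The much smaller group sits on an aromatic carbon of a six-membered aromatic ring of carbon only, para to a large group.

Among the compounds with values here, the one measured step that bears on this also exchanges a group on an aromatic carbon: a step that the two limits leave unreadable from compound 1 to compound 2. Within the data shown here, it gives no size to carry over, so the only guide is compound 2 and its limit. The expected change, a number no higher from compound 2 to compound 3 (the limit leaves the size open), is none beyond the scatter. For compound 3 the estimated value is 10000 nM, with an expected range from 3000 nM to 30000 nM.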

Compound 3, half-maximal cytotoxic concentration: > 10000 nM
Compound 3 was reported as a limit; the forecaster's own chance of this, stated with the estimate: 70%; the middle value sits exactly at the limit.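

In this assay, within the data shown here, compound 1, compound 2 and compound 3 all give limits and not numbers, so no step among them can be read: the limit of > 10000 nM in this assay, at which 3 of the 3 values shown sit.
From the compounds shown here alone, what stays open is the concentration at which any of these three compounds harms the cells, and whether they differ from one another at all.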